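Bulkier amine substituents on the coumarin ether chain

The source may report more compounds than this note shows. Statements on the series, on what has been measured and on what is new or still open speak of the compounds shown alone.

Measured compounds:
compound 1, `CC(C)=CCc1cc(C(=O)Nc2cc3ccc(OCCCNC(C)C)c(C)c3oc2=O)ccc1O`, 740 nM
compound 2, `CC(C)=CCc1cc(C(=O)Nc2cc3ccc(OCCCN(C)C4CCCCC4)c(C)c3oc2=O)ccc1O`, 1080 nM
compound 3, `CC(C)=CCc1cc(C(=O)Nc2cc3ccc(OCCCNc4ccccc4)c(C)c3oc2=O)ccc1O`, a limit of > 50000 nM

In a functional assay on MCF7 cells (Homo sapiens) for antiproliferative activity (a higher number here means a weaker inhibitor, a lower number a stronger inhibitor), compound 1 gives 740 nM, the lowest of the two numbers reported, with compound 2 nearest. The step of a 1.5-fold higher number from compound 1 to compound 2 (0.16 log units; within the scatter) shows that a larger saturated amine substituent leaves the result essentially unchanged. Compound 3 reports only a limit, > 50000 nM, in this assay. The step of an at least 67-fold higher number from compound 1 to compound 3 (1.82 log units; beyond the scatter) and the step of an at least 46-fold higher number from compound 2 to compound 3 (1.66 log units; beyond the scatter) both mark a large loss when the amine carries an aromatic group, as recorded in the limit of > 50000 nM in this assay, at which 1 of the 3 values shown sits.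

Compound 4, `CC(C)=CCc1cc(C(=O)Nc2cc3ccc(OCCCN[C@@H]4C[C@H]5CC[C@@H]4C5)c(C)c3oc2=O)ccc1O`, differs from compound 1 by a group of 7 heavy atoms (7 carbon; 2 five-membered non-aromatic rings of carbon only) in place of a group of 3 heavy atoms (3 carbon; no ring), on an amine nitrogen. The entering group is saturated, like those of compound 1 and compound 2, and unlike the anilino group of compound 3; the step from compound 1 to compound 2 is therefore the more relevant precedent, and it lay within the scatter. Compound 4 is consequently expected to give 900 nM, within 400 nM to 2500 nM, a step of a 1.2-fold higher number from compound 1 to compound 4 (0.09 log units; within the scatter) that is expected to be no larger than the scatter.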

Compound 4, half-maximal inhibitory concentration: 1030 nM
Compound 4: middle estimate off by 1.1-fold (0.06 log units), on the low side; the measured number falls inside the stated range.
By their numbers in this assay, from the lowest: compounds 1, 4 and 2 (each within the scatter of the next). At a limit, above all of these: compound 3.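

In this assay, a much larger saturated group, with 2 five-membered non-aromatic rings of carbon only, can stand on the amine nitrogen in place of isopropyl, with a 1.4-fold higher number from compound 1 to compound 4 (0.14 log units; within the scatter); the saturated chain carbon remains the nitrogen's only other neighbour. Compound 2 carries a methyl on its nitrogen as well as a ring, but a 1.0-fold lower number from compound 2 to compound 4 (0.02 log units; within the scatter), so these two saturated amine groups cannot be told apart here. A ring on the nitrogen therefore does not by itself go with the loss, given an at least 48-fold lower number from compound 3 to compound 4 (1.68 log units; beyond the scatter), and the value of compound 3 remains a limit: the limit of > 50000 nM in this assay, at which 1 of the 4 values shown sits.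

The compounds shown leave open whether a benzyl group, a morpholine or a longer chain would hold this level. They also leave open whether other stereoisomers of the group in compound 4 would give a different number.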